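This account rests on a few compounds, and the source may have more. Where it says the series, first, only, none or still open, it means among the compounds named here.

Compound 1 `Cc1cc(C)c(S(=O)(=O)N[C@@H](CNC(=O)CO[C@@H]2C[C@@H](CNc3ccccn3)N(CCCc3ccccc3)C2)C(=O)O)c(C)c1` — in an assay on a protein complex for inhibition of integrin alpha-5/beta-1 (Homo sapiens), read by ELISA (on this read-out lower numbers stand for stronger inhibition and higher numbers for weaker inhibition), compound 1 gives 670 nM.
Compound 2 `Cc1cc(C)c(S(=O)(=O)N[C@@H](CNC(=O)CO[C@H]2CN[C@H](CNc3ccccn3)C2)C(=O)O)c(C)c1` — in this assay compound 2 gives 286 nM.

Within the data shown here, compound 2 holds the lowest of the two numbers measured so far; its only neighbour is compound 1, and the step of a 2.3-fold lower number from compound 1 to compound 2 (0.37 log units; beyond the scatter) lies beyond the scatter. Compound 3 `COC(=O)N1C[C@H](OCC(=O)NC[C@H](NS(=O)(=O)c2c(C)cc(C)cc2C)C(=O)O)C[C@H]1CNc1ccccn1` has not yet been measured. It differs from compound 2 by methoxycarbonyl in place of hydrogen on an amine nitrogen in a ring. Among the measured compounds shown here, the one measured step that bears on this site is the change from compound 1 to compound 2, a 2.3-fold lower number from compound 1 to compound 2 (0.37 log units; beyond the scatter), where the 3-phenylpropyl group left the same ring nitrogen and the number fell. Methoxycarbonyl is a different group from 3-phenylpropyl, so that step carries over only loosely; it shows, however, that the one substituent tried on this nitrogen gave a higher number than hydrogen did, and nothing else in the series speaks to the point. Compound 3 is therefore expected to give a number somewhat higher than compound 2, with a 1.7-fold higher number from compound 2 to compound 3 (0.24 log units; within the scatter) as the expected step, yet not clearly outside the span already seen with compound 1. Compound 3 is estimated at 500 nM, with a range from 150 nM to 1600 nM.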

Compound 3, half-maximal inhibitory concentration: 15 nM
Compound 3: middle estimate off by 33-fold (1.52 log units), on the high side; measured number outside the range, below it.
By their numbers in this assay, from the lowest: compound 3; then compound 2; then compound 1.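

In this assay, the ring nitrogen proves to be a site where a substituent can lower the number well below that of the unsubstituted amine: a 19-fold lower number from compound 2 to compound 3 (1.28 log units; beyond the scatter). The earlier step pointed the other way, a 2.3-fold lower number from compound 1 to compound 2 (0.37 log units; beyond the scatter), so substitution on this nitrogen as such does not set the direction, and the two substituents tried so far differ widely, with a 45-fold lower number from compound 1 to compound 3 (1.65 log units; beyond the scatter). The data shown offer no measurement that would explain this difference between methoxycarbonyl and 3-phenylpropyl.

Still open, going by these compounds, is whether the lower number goes with a carbonyl on the ring nitrogen or needs the whole methoxycarbonyl group, a question on which an acetyl group, an ethoxycarbonyl group or a plain methyl on this nitrogen would bear. Also open, on these data alone, is whether the step from hydrogen to methoxycarbonyl keeps its size on the other integrins, as all the numbers here come from this assay.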